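The source may hold more compounds than are shown below. What is called first, only, known or untested is meant among the compounds shown, and "the series" means these compounds.

Compound 1 `Cn1cc(C2=C(c3nn(CCCN4CCCCC4)c4ncccc34)C(=O)N(c3ccccc3)C2=O)c2ccccc21` and compound 2 `CN1CCN(CCCn2nc(C3=C(c4cn(C)c5ccccc45)C(=O)NC3=O)c3cccnc32)CC1` are the two measured relatives of compound 3 `Cn1cc(C2=C(c3nn(CCCN4CCCCC4)c4ncccc34)C(=O)NC2=O)c2ccccc21`, which is still unmeasured. In a functional assay on A549 cells (Homo sapiens) for antiproliferative activity, read by MTT assay, with a stated time of 48 h (on this read-out lower numbers stand for stronger inhibition and higher numbers for weaker inhibition), compound 1 gives 20600 nM as its measured value. Compound 2 gives > 100000 nM in this assay and this is a limit of the assay, not a number. Going from compound 2 to compound 3 is a single change. That change piperidin-1-yl in place of 4-methylpiperazin-1-yl on a saturated chain carbon, three bonds along the chain from an aromatic nitrogen is piperidin-1-yl in place of 4-methylpiperazin-1-yl on a saturated chain carbon, three bonds along the chain from an aromatic nitrogen. Within the data shown here, no measured pair isolates this change, so the only guide is indirect. Compound 3 shares the 3-(piperidin-1-yl)propyl group with compound 1, which differs from it elsewhere in the core and gives 20600 nM in this assay with that group. A move toward stronger inhibition is therefore expected, though its size is uncertain and the assay might still report only a limit. The estimated step of an at least 2.8-fold lower number from compound 2 to compound 3 (0.45 log units; beyond the scatter) is expected to be moderate in size. For compound 3 the estimated value is 35000 nM with an expected range from 10000 nM to 100000 nM in this read-out.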

Compound 3, half-maximal inhibitory concentration: > 100000 nM
Compound 3: a limit, no number; the forecaster's own chance of this, stated with the estimate: 25%; middle value at least 2.8-fold (0.45 log units) from the limit.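

Compound 3 carries the same 3-(piperidin-1-yl)propyl group as compound 1. Yet in this assay compound 3 gives > 100000 nM, which is a limit of the assay and not a number. Among these compounds, this shows that the group alone does not secure a readable value, and the single change at the amide-type nitrogen in a ring, hydrogen in place of phenyl, gives an at least 4.8-fold higher number from compound 1 to compound 3 (0.68 log units; beyond the scatter), leaving compound 1 as the only one of the three with a measured number. The change from 4-methylpiperazin-1-yl to piperidin-1-yl on the chain cannot be read, since both of its ends are limits: the limit of > 100000 nM in this assay, at which 2 of the 3 values shown sit.

The compounds shown leave open whether a smaller or different group on that nitrogen, such as methyl or benzyl, would also give a readable number, or whether this takes phenyl itself. They also leave open how 4-methylpiperazin-1-yl behaves when phenyl sits on that nitrogen, and whether a shorter chain ending in a primary amine would shift the value in this read-out.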